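The compounds below may be only part of what the source reports. "The series", "measured", "known", "first", "only" and "open" are said of these compounds alone.

Three compounds have been measured in an assay on isolated protein for inhibition of histone deacetylase 8 (Homo sapiens), with a stated time of 1 h; on this read-out higher numbers stand for weaker inhibition and lower numbers for stronger inhibition:

Compound 1 `O=C(COc1ccc2cc(/C=C3/SC(=O)NC3=O)ccc2c1)Nc1ccc(Br)cc1` gives 16000 nM.
Compound 2 `COc1cccc(NC(=O)COc2ccc3cc(/C=C4/SC(=O)NC4=O)ccc3c2)c1` gives 7600 nM.
Compound 3 `O=C(COc1ccc2cc(/C=C3/SC(=O)NC3=O)ccc2c1)Nc1ccc(Br)cc1F` gives only a limit of the assay, > 50000 nM.

Going by the values given here, compound 3 therefore stands at the upper edge of what this assay reports, the one member of the three for which only a limit and no number is known (the limit of > 50000 nM in this assay, at which 1 of the 3 values shown sits). Compound 4 `O=C(COc1ccc2cc(/C=C3/SC(=O)NC3=O)ccc2c1)Nc1ccccc1` has not yet been measured; it differs from compound 3 by phenyl in place of 4-bromo-2-fluorophenyl on an amide-type nitrogen, so both the fluorine and the bromine are gone. Among the compounds with values here, two measured steps bear on this. The fluoro added from compound 1 to compound 3 gave an at least 3.1-fold higher number from compound 1 to compound 3 (0.49 log units; beyond the scatter), and compound 4 reverses that addition. Exchanging the whole group on the amide-type nitrogen from compound 1 to compound 2 gave a 2.1-fold lower number from compound 1 to compound 2 (0.32 log units; beyond the scatter), a modest shift. The expected step is a lowering of the number, an at least 2.5-fold lower number from compound 3 to compound 4 (0.39 log units; beyond the scatter), bringing compound 4 back near compound 1. The estimate for compound 4 in this assay is 20000 nM, within a range of 8000 nM to 60000 nM.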

Compound 4, half-maximal inhibitory concentration: 4500 nM
Compound 4: the middle estimate sits 4.4-fold (0.65 log units) above what was measured, and the stated range ends above it.
By their numbers in this assay, from the lowest: compounds 4 and 2 (each within the scatter of the next); then compound 1. At a limit, above all of these: compound 3.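

In this assay, the phenyl on the amide-type nitrogen needs no added group to hold its place: hydrogen in place of bromo gives a 3.6-fold lower number from compound 1 to compound 4 (0.55 log units; beyond the scatter), so the bromine offers no gain here. Hydrogen in place of methoxy gives a 1.7-fold lower number from compound 2 to compound 4 (0.23 log units; within the scatter), which leaves compound 2 and compound 4 not separable on this read-out. Phenyl in place of 4-bromo-2-fluorophenyl gives an at least 11-fold lower number from compound 3 to compound 4 (1.04 log units; beyond the scatter), and that size is a bound rather than a number, since compound 3 is known only as a limit: the limit of > 50000 nM in this assay, at which 1 of the 4 values shown sits.

Still open, going by these compounds, is whether fluoro without the bromine would raise the number on its own, as compound 3 carries both. Also open, on these data alone, is whether an amine or a carboxylic acid on this phenyl would bring the number below that of the bare ring.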